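This account rests on a few compounds, and the source may have more. Where it says the series, first, only, none or still open, it means among the compounds named here.

Of the compounds shown here, two that share a core have been measured so far in a physicochemical assay for lipophilicity, using the shake flask method, measured as octanol-water partition, at pH 7.4 (a higher number here means a more lipophilic compound, a lower number a more polar compound), and both returned a number. Compound 1 (`CC(=O)N[C@@H]1CCC[C@H](C(=O)Nc2cc(-c3cnn4c3CCCC4)ccn2)C1`) reads 2.4 here. Compound 2 (`CC(=O)N[C@@H]1CCC[C@H](C(=O)Nc2cc(-c3cnn4c3CC(C)(C)CC4)ccn2)C1`) reads 3.1 here and holds the higher of the two numbers, with a gap to compound 1 that lies beyond the usual scatter. The next compound in the account, compound 3 (`CC(=O)N[C@@H]1CCC[C@H](C(=O)Nc2cc(-c3cnn4c3CC(C)(C)CC4)c(F)cn2)C1`), still awaits its measurement. The change from compound 2 is fluoro in place of hydrogen on an aromatic carbon and amounts to fluoro in place of hydrogen on an aromatic carbon, two atoms from the ring nitrogen. Among the measured compounds shown here, no pair of measured compounds shows this replacement, so the data give no direct guide to its size, and the expectation rests on the structural change alone. An estimated step of a number 0.20 log units higher from compound 2 to compound 3 (within the scatter) is expected in this assay and would be a small rise that stays within the scatter. Compound 3 is estimated at 3.3 for now, with the expected range running from 3 to 3.6 at this stage.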

Compound 3, distribution coefficient: 3.6
The estimate for compound 3 lay 0.30 log units below the measured number, and the stated range covers the measured number.
By their numbers in this assay, from the lowest: compound 1; then compound 2; then compound 3.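

In this assay, fluoro in place of hydrogen on this aromatic carbon, ortho to a large group and two atoms from the ring nitrogen, gives a step of a number 0.50 log units higher from compound 2 to compound 3 (beyond the scatter). Among the compounds shown here, this is the first step that can be read for a change in one place, and it shows that this position is not silent in this assay. The entering group adds only one heavy atom, no ring, no hydrogen-bond donors or acceptors and no net charge, yet the shift lies beyond the usual scatter. Nothing measured here accounts for the size of this shift, so it stands as an observation for this one pair of compounds.

The compounds shown leave open how chloro, methoxy or a nitrile on the same aromatic carbon would compare with fluoro. They also leave open whether fluoro would give a step of similar size on compound 1, or at another carbon of the same six-membered aromatic ring, since a single pair cannot show how far this result extends.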